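The source may hold more compounds than are shown below. What is called first, only, known or untested is meant among the compounds shown, and "the series" means these compounds.

Measured so far:
Compound 1 `N#CC1=C(N)Oc2c(N)cc3nc4ccccc4nc3c2C12C(=O)N(Cc1cnnn1-c1ccc(Cl)cc1)c1ccccc12` — in a functional assay on HCT-116 cells (Homo sapiens) for antiproliferative activity, read by MTT assay, with a stated time of 48 h (on this read-out higher numbers stand for weaker inhibition and lower numbers for stronger inhibition), compound 1 gives > 50000 nM, a limit of the assay rather than a number.
Compound 2 `N#CC1=C(N)Oc2c(N)cc3nc4ccccc4nc3c2C12C(=O)N(Cc1cnnn1-c1ccccc1Cl)c1ccccc12` — in this assay compound 2 gives > 50000 nM, likewise a limit.

The step from compound 1 to compound 2 is a step that the two limits leave unreadable from compound 1 to compound 2. Both values rest on (the limit of > 50000 nM in this assay, at which 2 of the 2 values shown sit), so compound 2 stands at the limit of this assay and nowhere more precise than that.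

Compound 3 `N#CC1=C(N)Oc2c(N)cc3nc4ccccc4nc3c2C12C(=O)N(Cc1cnnn1-c1cccc(C(F)(F)F)c1)c1ccccc12` differs from compound 2 by 3-(trifluoromethyl)phenyl in place of 2-chlorophenyl on an aromatic nitrogen. Among the measured compounds shown here, only one measured step touches this position, the one from compound 1 to compound 2, and its size is unreadable; what the two measured compounds do show is that both sit at the limit. No size or direction of change in this assay can therefore be read from the data.

Compound 3 is accordingly expected to give about 50000 nM, estimated between 20000 nM and 100000 nM, most likely reported again as a limit. The estimated step is a number no higher from compound 2 to compound 3 (the limit leaves the size open).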

Compound 3, half-maximal inhibitory concentration: 18900 nM
Compound 3: the middle estimate sits 2.6-fold (0.42 log units) above what was measured; the measured number lies below the stated range.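

In this assay, the group on the aromatic nitrogen proves able to move the read-out off the limit, with an at least 2.6-fold lower number from compound 2 to compound 3 (0.42 log units; beyond the scatter) and an at least 2.6-fold lower number from compound 1 to compound 3 (0.42 log units; beyond the scatter). The earlier pair showed only that the 4-chlorophenyl and 2-chlorophenyl groups both left the number at a limit, and the step between them cannot be read, whereas compound 3, with its 3-(trifluoromethyl)phenyl group, is the only compound shown that gives an actual number. The true size of both new steps stays open because each starts from a compound that gives only a limit: the limit of > 50000 nM in this assay, at which 2 of the 3 values shown sit.

The compounds shown do not separate the effect of the trifluoromethyl group from that of its place on the phenyl ring. On these data alone, how a plain phenyl, a methoxyphenyl or an aminophenyl group would read here also remains open.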